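Replacing the trifluoromethylpyrazole with a dimethylmorpholine

The source may report more compounds than this note shows. Statements on the series, on what has been measured and on what is new or still open speak of the compounds shown alone.

Measured so far:
compound 1, `CCOc1cc(NC(=O)NCc2cc(C)c(-c3cn(C)nc3C)cn2)cc(Cl)n1`, gives 40 nM in a functional assay on CHO cells for antagonist activity at sphingosine 1-phosphate receptor 2 (Homo sapiens), read by fluorescence and calcium flux, with a stated time of 3 min; on this read-out higher numbers stand for weaker inhibition and lower numbers for stronger inhibition
compound 2, `CCOc1cc(NC(=O)NCc2cc(C)c(-c3cn(C)nc3C(F)(F)F)cn2)cc(Cl)n1`, gives 11000 nM in this assay

In this assay, among the measured compounds shown here, compound 2 has the highest of the two numbers and is therefore the weaker inhibitor; its only neighbour is compound 1, and the single measured step is a 280-fold higher number from compound 1 to compound 2 (2.44 log units; beyond the scatter). Compound 3, `CCOc1cc(NC(=O)NCc2cc(C)c(N3CC(C)OC(C)C3)cn2)cc(Cl)n1`, differs from compound 2 by 2,6-dimethylmorpholin-4-yl in place of 1-methyl-3-(trifluoromethyl)-1H-pyrazol-4-yl on an aromatic carbon. That step concerns the same place but not a morpholine, so it only shows that a change there can move the number strongly, in either direction. Compound 3 is therefore expected, with wide uncertainty, at 600 nM, between 60 nM and 6000 nM, which would mean an 18-fold lower number from compound 2 to compound 3 (1.26 log units; beyond the scatter).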

Compound 3, half-maximal inhibitory concentration: 16000 nM
Compound 3: the middle estimate sits 27-fold (1.43 log units) below what was measured; measured number outside the range, above it.
By their numbers in this assay, from the lowest: compound 1; then compounds 2 and 3 (each within the scatter of the next).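

In this assay the 2,6-dimethylmorpholin-4-yl group of compound 3 and the 1-methyl-3-(trifluoromethyl)-1H-pyrazol-4-yl group of compound 2 cannot be told apart, with a 1.5-fold higher number from compound 2 to compound 3 (0.16 log units; within the scatter). Set against the 1,3-dimethyl-1H-pyrazol-4-yl group, the morpholine gives a 400-fold higher number from compound 1 to compound 3 (2.60 log units; beyond the scatter), so among these three groups only the dimethylpyrazole of compound 1 keeps the number low. No measurement at hand explains this difference. Still open, on these data alone, is how a morpholine without its two methyl groups, or a pyrazole carrying an ethyl group in place of the 3-methyl, would read at this position.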